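The source may report more compounds than this note shows. Statements on the series, on what has been measured and on what is new or still open speak of the compounds shown alone.

Measured so far:
Compound 1, `Cc1cc(C)cc(NC(=O)COc2cc(C)nc3ccc(C)cc23)c1`. In an ADME assay on microsomes from liver (Mus musculus) for metabolic stability, read by LC-MS, using NADPH, with a stated time of 30 min, tested at 0.5 uM (a lower number here means that the compound disappears faster, a higher number that the compound lasts longer), compound 1 gives only a limit, < 0.0834 h.
Compound 2, `COc1ccc2nc(C)cc(OC(C)(C)C(=O)Nc3cc(C)cc(C)c3)c2c1`. In this assay compound 2 gives only a limit, < 0.0834 h.
Compound 3, `COc1ccc2nc(C)cc(OCC(=O)Nc3cccc(C)c3)c2c1`. In this assay compound 3 gives only a limit, < 0.0834 h.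

Compound 3 stands where every measured compound in this set stands: its half-life in this assay is reported as a limit of the assay rather than as a number. The same is true of compound 1 and compound 2, which is the whole of the evidence here (the limit of < 0.0834 h in this assay, at which 3 of the 3 values shown sit). For the measured compounds named here, no pair of measured compounds that differ in a single place has been sized, so there is no measured step to lean on.

Compound 4, `COc1ccc2nc(C)cc(OCC(=O)Nc3cc(C)c(F)c(C)c3)c2c1`, differs from compound 3 in one place: 4-fluoro-3,5-dimethylphenyl in place of 3-methylphenyl on an amide-type nitrogen. With all three recorded values sitting at the same limit, the expectation for this change is no step beyond the usual scatter in this assay. The estimated step from compound 3 to compound 4 is a step that the limit leaves unreadable from compound 3 to compound 4. Compound 4 is therefore expected to give about 0.06 h in this assay, within an estimated range from 0.03 h to 0.12 h, and most likely to be reported once more only as a limit.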

Compound 4, half-life: < 0.0834 h
Compound 4 ended at the assay's limit; the forecaster's own chance of this, stated with the estimate: 80%; the middle value does not contradict the limit.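

Compound 3 and compound 4 are both reported in this assay only as a limit, not as a number, so no step between them can be read: the limit of < 0.0834 h in this assay, at which 4 of the 4 values shown sit.

The compounds shown leave open how long any of them actually lasts in this assay and whether 4-fluoro-3,5-dimethylphenyl in place of 3-methylphenyl changes that half-life at all.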